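A few compounds are considered here, and "the series" means these few. Any claim that something is new, unique, unknown or untested is made for them only; others in the source may bear on it.

Series notes. Among the measured compounds shown here, in a functional assay on A549 cells (Homo sapiens) for antiproliferative activity, read by sulforhodamine B assay, with a stated time of 48 h (a lower number here means a stronger inhibitor of growth, a higher number a weaker inhibitor of growth), compound 2 `CC(=O)OC[C@H]1O[C@@H](OCc2noc(-c3ccc([N+](=O)[O-])cc3)n2)[C@@H]2OC3(CCCC3)O[C@@H]21` gives 29000 nM, the higher of the two numbers measured so far. Compound 1 `Nc1nnc(SC[C@H]2O[C@@H](OCc3noc(-c4ccc([N+](=O)[O-])cc4)n3)[C@@H]3OC4(CCCC4)O[C@@H]32)s1` gives 14000 nM in this assay. For the measured compounds named here, the one measured step is a 2.1-fold higher number from compound 1 to compound 2 (0.32 log units; beyond the scatter). Compound 3 `Cc1ccc(S(=O)(=O)OC[C@H]2O[C@@H](OCc3noc(-c4ccc([N+](=O)[O-])cc4)n3)[C@@H]3OC4(CCCC4)O[C@@H]32)cc1` differs from compound 2 by (4-methylphenyl)sulfonyl in place of acetyl on an oxygen on a saturated carbon. Going by the values given here, no measured step exchanges one group on this oxygen for another, so the only guide is the modest step of a 2.1-fold higher number from compound 1 to compound 2 (0.32 log units; beyond the scatter). A step of that order or none beyond the scatter is therefore expected, a 1.2-fold lower number from compound 2 to compound 3 (0.06 log units; within the scatter). Compound 3 is estimated at 25000 nM, with a range of 8000 nM to 70000 nM.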

Compound 3, concentration for 50% growth inhibition: > 100000 nM
Compound 3 ended at the assay's limit (the forecaster's own chance of this, stated with the estimate: 15%); at least 4.0-fold (0.60 log units) between middle value and limit.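

In this assay compound 3 gives > 100000 nM, a limit of the assay and not a number. Exchanging acetyl for (4-methylphenyl)sulfonyl on this oxygen gives an at least 3.4-fold higher number from compound 2 to compound 3 (0.53 log units; beyond the scatter), and ((4-methylphenyl)sulfonyl)oxy in place of (5-amino-1,3,4-thiadiazol-2-yl)sulfanyl gives an at least 7.1-fold higher number from compound 1 to compound 3 (0.85 log units; beyond the scatter), so the group at this position can shift the read-out further than the earlier step showed. Both sizes are floors, and the true gaps remain unread: the limit of > 100000 nM in this assay, at which 1 of the 3 values shown sits.

Open, as far as these compounds go, is whether the sulfonyl or the aromatic ring of the entering group accounts for the step. Also open, from the compounds shown here alone, is how a free hydroxyl or an amine at this position would compare with compound 1.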